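Cytotoxicity notes: ethoxycarbonyl to benzyloxycarbonyl

The compounds below may be only part of what the source reports. "The series", "measured", "known", "first", "only" and "open" are said of these compounds alone.

Measured in an ADME assay on HEK293 cells (Homo sapiens) for cytotoxicity, with a stated time of 72 h; on this read-out lower numbers stand for an effect already at smaller amounts and higher numbers for an effect only at larger amounts of compound:
- compound 1 `C=C[C@@](C)(/C=C/c1ccc(O)c(/C=C/C#N)c1)CCC=C(C)C`: > 36600 nM
- compound 2 `C=C[C@@](C)(/C=C/c1ccc(O)c(/C=C/C(=O)OCC)c1)CCC=C(C)C`: > 36600 nM

Both entries are limits of the assay and not numbers. Going by the values given here, compound 2 stands only at a limit, and the one other value shown is a limit too, so the series so far reads as the limit of > 36600 nM in this assay, at which 2 of the 2 values shown sit.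

Compound 3 `C=C[C@@](C)(/C=C/c1ccc(O)c(/C=C/C(=O)OCc2ccccc2)c1)CCC=C(C)C` differs from compound 2 by phenyl in place of methyl on a saturated chain carbon bound to an oxygen next to a carbonyl group, or ethoxycarbonyl to benzyloxycarbonyl when cut one bond further out.

Among the compounds with values here, the only measured step bearing on this is a step that the two limits leave unreadable from compound 1 to compound 2, with ethoxycarbonyl in place of cyano. Within the data shown here, it offers no size to carry over, so no step of definite size or direction is expected in this assay, and another report as a limit is the likeliest outcome. The expected move, an at least 1.0-fold lower number from compound 2 to compound 3 (0.00 log units; that floor lies within the scatter), is an estimate made against a limit only. For compound 3 the estimate is 36000 nM, with an expected range of 15000 nM to 70000 nM.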

Compound 3, half-maximal effective concentration: > 36600 nM
Compound 3 ended at the assay's limit (the forecaster's own chance of this, stated with the estimate: 75%); middle value at least 1.0-fold (0.00 log units) from the limit.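

Going by these compounds alone, no step among compound 1, compound 2 and compound 3 can be read. All three stand at one limit, which is a limit of the assay and not a number: the limit of > 36600 nM in this assay, at which 3 of the 3 values shown sit.

Left open is whether cyano, ethoxycarbonyl and benzyloxycarbonyl differ at all in this assay, and at what concentration any of these compounds would give an effect.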